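A 1H-1,2,3-triazol-5-yl in place of 1H-pyrazol-5-yl

The source may hold more compounds than are shown below. What is called first, only, known or untested is meant among the compounds shown, and "the series" means these compounds.

Of the compounds shown here, three that share one core have so far been measured in a physicochemical assay for solubility, read by nephelometry, measured as kinetic solubility, at pH 6.5 (a higher number here means a more soluble compound, a lower number a less soluble compound), and they differ in the group on a carbonyl carbon. Compound 1 (`NCc1csc(NC(=O)c2ccon2)n1`) gives 50 ug/mL in this series of readings. Compound 2 (`NCc1csc(NC(=O)c2cnnn2Cc2ccccc2)n1`) gives the same reading of 50 ug/mL in this assay as well.

Compound 3 (`NCc1csc(NC(=O)c2ccn[nH]2)n1`) reads > 100 ug/mL in this assay and that entry is a limit, not a number. Compound 3 therefore stands at the limit of > 100 ug/mL in this assay, at which 1 of the 3 values shown sits, and no closer figure exists for it.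

Still unmeasured is compound 4 (`NCc1csc(NC(=O)c2cnn[nH]2)n1`), which differs from compound 3 on a carbonyl carbon whose other neighbours are: amide-type nitrogen. The change is 1H-1,2,3-triazol-5-yl in place of 1H-pyrazol-5-yl on a carbonyl carbon and it puts 1H-1,2,3-triazol-5-yl in place of 1H-pyrazol-5-yl.

Among the compounds with values here, the only measured step that bears on this is an at least 2.0-fold higher number from compound 1 to compound 3 (0.30 log units; that floor lies within the scatter) and it gives a floor rather than a size. On that evidence, no step beyond the scatter is expected in this assay in either direction. The estimated step is an at least 1.1-fold lower number from compound 3 to compound 4 (0.04 log units; that floor lies within the scatter) and a reading at the limit is also expected to be quite possible. In this assay compound 4 is expected at 90 ug/mL with an estimated range from 45 ug/mL to 130 ug/mL as its likely span.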

Compound 4, solubility: > 100 ug/mL
Compound 4 ended at the assay's limit; the forecaster's own chance of this, stated with the estimate: 50%; middle value at least 1.1-fold (0.04 log units) away from the limit.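

In this assay, the 1H-1,2,3-triazol-5-yl on a carbonyl carbon gives an at least 2.0-fold higher number from compound 1 to compound 4 (0.30 log units; that floor lies within the scatter), so the comparison with the 1,2-oxazol-3-yl now has a second partner besides the 1H-pyrazol-5-yl. New here is a step at the aromatic nitrogen itself, hydrogen in place of benzyl, which gives an at least 2.0-fold higher number from compound 2 to compound 4 (0.30 log units; that floor lies within the scatter); this too is only a floor, and neither floor goes beyond the scatter. The step from compound 3 to compound 4 cannot be read, as both readings are limits and not numbers, so the swap of 1H-pyrazol-5-yl for 1H-1,2,3-triazol-5-yl has no measurable size here, and compound 4 now joins compound 3 at the top of the range: the limit of > 100 ug/mL in this assay, at which 2 of the 4 values shown sit.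

From the compounds shown here alone, how far compound 3 and compound 4 actually lie from each other stays open, and so does the true size of either floor. Also open, going by these compounds, is where a smaller group such as methyl in place of benzyl on the aromatic nitrogen would read, or a 1H-tetrazol-5-yl on the same carbonyl carbon.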